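A few compounds are considered here, and "the series" means these few. Any claim that something is new, unique, unknown or untested is made for them only; others in the source may bear on it.

Measured compounds in a physicochemical assay for acid dissociation:
compound 1, `CN(Cc1ccc(N(C)C)cc1)Cc1ccccc1CNc1ccnc2cc(Cl)ccc12`, gives 9.71;
compound 2, `COc1ccc(CN(C)Cc2ccc(CNc3ccnc4cc(Cl)ccc34)cc2)cc1`, gives 9.7;
compound 3, `CN(Cc1ccc(CNc2ccnc3cc(Cl)ccc23)cc1)Cc1ccc(N(C)C)cc1`, gives 9.66.

All three compounds share an amine that carries two benzyl arms, and the question in this assay is how readily that amine gives up its proton. Compound 1 and compound 3 are built from the same atoms joined differently; the difference between the two cores is not broken down here. Their values lie within the scatter of one another, as do those of compound 1 and compound 2.

One structural change is seen twice. From compound 3 to compound 2 it reads (methoxy in place of dimethylamino on an aromatic carbon), and it made a step of a number 0.04 log units higher from compound 3 to compound 2 (within the scatter). From compound 1 to compound 4, `COc1ccc(CN(C)Cc2ccccc2CNc2ccnc3cc(Cl)ccc23)cc1`, the same change is made: methoxy in place of dimethylamino on an aromatic carbon. The place is described in the same words in both cases, so this is the same change on a different core.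

Compound 4 has not yet been measured in this assay. Because the step of a number 0.04 log units higher from compound 3 to compound 2 (within the scatter) was within the scatter, compound 4 is expected to sit close to compound 1, with a step of about a number 0.04 log units higher from compound 1 to compound 4 (within the scatter). The estimate for compound 4 in this assay is 9.75, expected to fall between 9.5 and 10.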

Compound 4, acid dissociation constant: 9.85
Beside the measured number, compound 4's estimate is 0.10 log units below it; the measured number falls inside the stated range.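

Replacing dimethylamino with methoxy on the core of compound 1 gives, in this assay, a step of a number 0.14 log units higher from compound 1 to compound 4 (within the scatter) and on the other core the same replacement gave a step of a number 0.04 log units higher from compound 3 to compound 2 (within the scatter) so on both cores the step stays inside the ordinary spread of repeated measurements. Within the data shown here, this shows that, for these two pairs, carrying the change from one core to the other brought no step that can be told apart from that spread; it does not show that the two groups are interchangeable in general, and two pairs are too few to set a rule for the whole series. Nothing shown here explains why the number stays within the scatter in either pair.

The compounds shown carry only dimethylamino or methoxy on that aromatic carbon, para to a large group, so it stays open whether a different group there, such as a carboxylic acid, a primary amine or a longer chain like butoxy, would also leave the number within the scatter. As far as these compounds go, it also stays open whether such a group would give matching steps on the two cores, which is the real test of whether a change carries from one core to another.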